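This account rests on a few compounds, and the source may have more. Where it says the series, first, only, none or still open, it means among the compounds named here.

Measured compounds:
Compound 1 `Clc1ccc(Cc2nn3cc(-c4ccc(Br)cc4)nc3s2)cc1` — in a functional assay on L1210 cells (Mus musculus) for cytotoxicity, with a stated time of 48 h (on this read-out higher numbers stand for weaker inhibition and lower numbers for stronger inhibition), compound 1 gives > 250000 nM, a limit of the assay.
Compound 2 `Clc1ccc(Cc2nn3c(Br)c(-c4ccc(Br)cc4)nc3s2)cc1` — in this assay compound 2 gives > 250000 nM, also a limit.
Compound 3 `N#CSc1c(-c2ccc(F)cc2)nc2sc(Cc3ccc(Cl)cc3)nn12` — in this assay compound 3 gives 23000 nM.

Going by the values given here, compound 3 holds the only number in this set; the other two values are limits, as noted in the limit of > 250000 nM in this assay, at which 2 of the 3 values shown sit. Among the compounds with values here, the only measured step, a step that the two limits leave unreadable from compound 1 to compound 2, is unreadable for the same reason. Compound 4 `N#CSc1c(-c2ccc(Br)cc2)nc2sc(Cc3ccc(Cl)cc3)nn12` differs from compound 3 by bromo in place of fluoro on an aromatic carbon. Within the data shown here, no measured step involves this exchange, and the one measured step cannot be read, so nothing anchors the expectation beyond the value of compound 3 itself. The expected step is a 1.2-fold lower number from compound 3 to compound 4 (0.06 log units; within the scatter), within the scatter. Compound 4 is expected at 20000 nM, with a range from 7000 nM to 60000 nM.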

Compound 4, half-maximal inhibitory concentration: 81000 nM
Estimate against measurement, compound 4: 4.1-fold (0.61 log units) below, and the stated range ends below it.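

The change from 4-fluorophenyl to 4-bromophenyl gives a 3.5-fold higher number from compound 3 to compound 4 (0.55 log units; beyond the scatter) in this assay and so shows that the number responds to the halogen at this position. Going by these compounds alone, on the shared core, cyanosulfanyl in place of bromo gives an at least 3.0-fold lower number from compound 2 to compound 4 (0.48 log units; beyond the scatter) and cyanosulfanyl in place of hydrogen gives an at least 3.0-fold lower number from compound 1 to compound 4 (0.48 log units; beyond the scatter) and these are the first readable steps at that aromatic carbon. Both rest on limits of the assay and give only a minimum size, while the step between compound 1 and compound 2 cannot be read.

Still open, going by these compounds, is how methoxy or an amine in place of the halogen would read. Also open, on these data alone, is whether a nitrile or a longer chain in place of cyanosulfanyl keeps the number clear of the limit.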